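The source may report more compounds than this note shows. Statements on the series, on what has been measured and on what is new or still open speak of the compounds shown alone.

Compound 1, with the structure `CC1(c2ccccc2)CC(=O)N(CC(=O)N2CCN(c3ccc(Cl)cc3)CC2)C1=O`, is one of three measured members of a small series built on a shared core. In a functional assay on the whole organism (strain CD-1) with Mus musculus as the target, in the maximal electroshock model, with a stated time of 0.5 h (a lower number here means that less compound is needed, a higher number that more compound is needed for the effect), compound 1 gives "not active" (no number reported), so no single number stands for it, and the same is true of a second member of the series. Compound 3, `CC1(c2ccccc2)CC(=O)N(CC(=O)N2CCN(c3cccc(Cl)c3Cl)CC2)C1=O`, in this assay gives "not active" (no number reported). Among the compounds with values here, the one member with a number is compound 2, `COc1ccccc1N1CCN(C(=O)CN2C(=O)CC(C)(c3ccccc3)C2=O)CC1`, which in this assay gives 100 mg/kg. Within the data shown here, no step between measured compounds that differ in a single place is available, so compound 1 stands among the entries of the series for which no value can be placed on a scale.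

The step to compound 4, `CC1(c2ccccc2)CC(=O)N(CC(=O)N2CCN(c3cccc(C(F)(F)F)c3)CC2)C1=O`, is the change (3-(trifluoromethyl)phenyl in place of 4-chlorophenyl on an amine nitrogen in a ring). The difference lies only in the group carried on that ring nitrogen. Among the measured compounds shown here, with no measured step of the same kind to lean on, the size and direction of the step in this assay cannot be read from the series itself; the two entries without a number and the single value of compound 2 are all that is known. Compound 4 is therefore expected to give roughly 100 mg/kg, with a plausible range from 50 mg/kg to 300 mg/kg, and a considerable chance that it too is reported without a number.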

Compound 4, minimum effective dose: 300 mg/kg
The estimate for compound 4 lay 3.0-fold (0.48 log units) below the measured number; the measured number falls inside the stated range.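

In this assay compound 4 gives 300 mg/kg, whereas compound 1 gives "not active" (no number reported), so with 3-(trifluoromethyl)phenyl in place of 4-chlorophenyl on the ring nitrogen the series gains a second entry with a number; the steps that involve an entry without a number cannot be read as a size. Within the data shown here, the one readable step, a 3.0-fold higher number from compound 2 to compound 4 (0.48 log units; beyond the scatter), comes with 3-(trifluoromethyl)phenyl in place of 2-methoxyphenyl and shows that the group at this position can shift the required dose, with 2-methoxyphenyl needing the lower dose of this pair. Nothing at hand accounts for either the step or the contrast with the entries without a number.

The compounds shown leave open how an unsubstituted phenyl, a pyridine ring or a benzyl group on the same ring nitrogen would compare in this assay. All of them also keep the methyl and phenyl groups of the shared core, so it remains open whether the same order among these aryl groups would hold with an ethyl group in place of that methyl.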